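Methyl on the phenyl ring: compound 3 to compound 4

The source may hold more compounds than are shown below. What is called first, only, known or untested is meant among the compounds shown, and "the series" means these compounds.

Measured compounds: compound 1 `O=C(Nc1nn[nH]n1)c1cc(Cl)cc(-c2ccccc2)n1` gives 40%; compound 2 `Cc1cccc(-c2cc(C)cc(C(=O)Nc3nn[nH]n3)n2)c1` gives 51%; compound 3 `CCCCc1cc(C(=O)Nc2nn[nH]n2)nc(-c2ccccc2)c1` gives 56% in a functional assay on the whole organism with Rattus norvegicus as the target, at a dose of 1 mg/kg by the oral route; on this read-out higher numbers stand for a stronger effect at the one dose given and lower numbers for a weaker effect.

Compound 3 carries a butyl group where compound 1 carries chloro, and a number 16 percentage points higher from compound 1 to compound 3 (beyond the scatter) lies beyond the scatter. Compound 2, which differs from compound 3 in more than one place, gives a number within the scatter of compound 3, so no ordering between those two can be drawn. Compound 4 `CCCCc1cc(C(=O)Nc2nn[nH]n2)nc(-c2cccc(C)c2)c1` differs from compound 3 by methyl in place of hydrogen on an aromatic carbon. For the measured compounds named here, no measured step isolates this change, and compound 2 shows that a methyl on the phenyl ring coexists with a number close to that of compound 3. Compound 4 is therefore expected to show a number 1 percentage points higher from compound 3 to compound 4 (within the scatter), and its estimated value is 57% (range 42% to 72%).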

Compound 4, a percentage reported as inhibition, in the whole organism at one dose (the size of the read-out at that dose, not a potency): 36%
For compound 4 the middle estimate is 21 percentage points above the measured one; measured number outside the range, below it.
By their numbers in this assay, from the lowest: compounds 4 and 1 (each within the scatter of the next); then compounds 2 and 3 (each within the scatter of the next).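

In this assay, for the compounds shown here, methyl on the phenyl ring is not a neutral change when butyl is present on the core (a number 20 percentage points lower from compound 3 to compound 4 (beyond the scatter)), which the earlier compounds could not show. With the 3-methylphenyl group held constant, the methyl-to-butyl change by propyl in place of hydrogen also lowers the number (a number 15 percentage points lower from compound 2 to compound 4 (beyond the scatter)), so the effect of the butyl group depends on the phenyl group it is paired with. No evidence is available that explains either drop.

On these data alone, it remains open whether a fluoro or methoxy group at this place on the phenyl ring would behave like methyl, and how an ethyl or propyl chain would compare with butyl on the 3-methylphenyl compounds.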